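This account rests on a few compounds, and the source may have more. Where it says the series, first, only, none or still open, it means among the compounds named here.

Series notes, measured so far:

- compound 1 `COc1cc(-c2cccc3nc(-c4ccccc4)oc23)cc(OC)c1OC`: 3500 nM
- compound 2 `COc1cc(-c2cccc3nc(-c4ccc(F)cc4)oc23)cc(OC)c1OC`: > 25000 nM, a limit of the assay
- compound 3 `COc1cc(-c2cccc3nc(-c4cccc(O)c4)oc23)cc(OC)c1OC`: 5500 nM

All three values come from a functional assay on U-251 cells (Homo sapiens) for antiproliferative activity, read by MTT assay, with a stated time of 48 h; on this read-out higher numbers stand for weaker inhibition and lower numbers for stronger inhibition. Compound 3 stands within the scatter of compound 1, as a 1.6-fold higher number from compound 1 to compound 3 (0.20 log units; within the scatter) shows. Compound 2 is recorded only as a limit, so the steps that touch it, an at least 7.1-fold higher number from compound 1 to compound 2 (0.85 log units; beyond the scatter) and an at least 4.5-fold lower number from compound 2 to compound 3 (0.65 log units; beyond the scatter), are bounds and not exact sizes.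

Compound 4 `COc1cc(-c2cccc3nc(-c4cccc(N)c4)oc23)cc(OC)c1OC` carries amino in place of hydroxy on an aromatic carbon, meta to a large group: amino in place of hydroxy on an aromatic carbon. Going by the values given here, no measured step makes this exchange directly. The closest guide is a 1.6-fold higher number from compound 1 to compound 3 (0.20 log units; within the scatter), where a hydroxy group on the 3-hydroxyphenyl ring leaves the number within the scatter. The fluoro step, to the 4-fluorophenyl ring of compound 2, is a different group in a different place and bears on this change only weakly.

No step beyond the scatter is therefore expected, though the range stays wide on so few compounds. An estimated 1.4-fold lower number from compound 3 to compound 4 (0.14 log units; within the scatter) is expected in this assay. For compound 4 the expected value is 4000 nM, with an estimated range of 1300 nM to 13000 nM.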

Compound 4, half-maximal inhibitory concentration: 2200 nM
Estimate against measurement, compound 4: 1.8-fold (0.26 log units) above; the range from low to high includes it.
By their numbers in this assay, from the lowest: compounds 4, 1 and 3 (each within the scatter of the next, the first and the last beyond it). At a limit, above all of these: compound 2.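

In this assay, going by these compounds alone, a 2.5-fold lower number from compound 3 to compound 4 (0.40 log units; beyond the scatter) is the first change at this place, meta to a large group, to lie beyond the scatter, even though hydroxy and amino have the same counts of heavy atoms, hydrogen-bond donors and hydrogen-bond acceptors. Set against hydrogen at the same place, amino gives a 1.6-fold lower number from compound 1 to compound 4 (0.20 log units; within the scatter) and hydroxy gives a 1.6-fold higher number from compound 1 to compound 3 (0.20 log units; within the scatter), so the two groups separate from each other but neither separates from hydrogen. Compound 2 stands at a limit of the assay, so an at least 11-fold lower number from compound 2 to compound 4 (1.05 log units; beyond the scatter) is a bound and not an exact size: the limit of > 25000 nM in this assay, at which 1 of the 4 values shown sits.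

The compounds shown leave open whether a methylamino or an acetamide group at this place would follow amino. They also leave open whether amino would give a step of this size elsewhere on the same ring.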